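The compounds below may be only part of what the source reports. "The series", "measured", "known", "first", "only" and "open" are said of these compounds alone.

Measured so far:
compound 1 `CC(=O)Oc1ccc2c(c1)C(C)=CC(C)(C)N2Cc1cccc(C#N)c1`: 31000 nM
compound 2 `CC(=O)Oc1ccc2c(c1)C(C)=CC(C)(C)N2Cc1ccc(C)cc1`: 21000 nM

Within the data shown here, in an ADME assay on L6 cells (Rattus norvegicus) for cytotoxicity, read by resazurin assay, with a stated time of 70 h (a higher number here means a weaker inhibitor, a lower number a stronger inhibitor), compound 2 stands at 21000 nM, within the scatter of compound 1, the only other compound measured. Compound 3 `CC(=O)Oc1ccc2c(c1)C(C)=CC(C)(C)N2Cc1cccc(Cl)c1` differs from compound 2 at a single place: 3-chlorophenyl in place of 4-methylphenyl on a saturated chain carbon bound to a nitrogen on an aromatic ring in a ring. It carries 3-chlorophenyl in place of 4-methylphenyl on a saturated chain carbon bound to a nitrogen on an aromatic ring in a ring.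

Among the measured compounds shown here, only one measured step bears on this, a swap at that same place: a 1.5-fold lower number from compound 1 to compound 2 (0.17 log units; within the scatter). That single step exchanged 3-cyanophenyl for 4-methylphenyl and stayed small, so it is thin but consistent evidence. No step beyond the scatter is therefore expected, and the estimated step is a 1.1-fold higher number from compound 2 to compound 3 (0.06 log units; within the scatter). For compound 3 the expected value is 24000 nM, with an estimated range of 12000 nM to 48000 nM.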

Compound 3, half-maximal inhibitory concentration: 29000 nM
Compound 3: the middle estimate sits 1.2-fold (0.08 log units) below what was measured; low and high end bracket the measured number.
By their numbers in this assay, from the lowest: compounds 2, 3 and 1 (each within the scatter of the next).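

In this assay, the new compound adds a third aryl group at this place, on a saturated chain carbon bound to a nitrogen on an aromatic ring in a ring, and a 1.4-fold higher number from compound 2 to compound 3 (0.14 log units; within the scatter) shows that 3-chlorophenyl reads like 4-methylphenyl there. Among these compounds, it also gives the first pair that keeps the phenyl substitution pattern fixed and changes only the substituent, chloro in place of cyano on an aromatic carbon, where a 1.1-fold lower number from compound 1 to compound 3 (0.03 log units; within the scatter) again stays inside the scatter. No measurement here speaks to why these groups read alike.

The compounds shown leave open whether a basic amine or a carboxylic acid on the benzyl ring would move the number beyond the scatter. They also leave open whether a longer chain between the ring and the nitrogen would do so.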